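Acyl amidrazone series: chlorophenyl placement on the imine nitrogen

The source may report more compounds than this note shows. Statements on the series, on what has been measured and on what is new or still open speak of the compounds shown alone.

Measured so far in an assay on isolated protein for binding affinity to corticotropin-releasing factor receptor 1 (Homo sapiens); a higher number here means a weaker inhibitor, a lower number a stronger inhibitor:
compound 1 `CC(=O)/C(=N\c1ccc(Cl)cc1)NNc1ccccc1C` gives 1830 nM
compound 2 `C#Cc1cccc(/N=C(/NNc2ccccc2C)C(C)=O)c1` gives 62 nM
compound 3 `CC(=O)/C(=N\c1ccccc1Cl)NNc1ccccc1Cl` gives only a limit, > 10000 nM

Compound 3 stands at the limit of this assay, so its result is a limit rather than a number, (the limit of > 10000 nM in this assay, at which 1 of the 3 values shown sits). Compound 4 `CC(=O)/C(=N\c1ccc(Cl)cc1)NNc1ccccc1Cl` has not yet been measured. Compound 4 differs from compound 3 by 4-chlorophenyl in place of 2-chlorophenyl on a double-bonded nitrogen. Compound 1 also carries 4-chlorophenyl on a double-bonded nitrogen and gives 1830 nM. A step towards stronger binding, beyond the scatter, is therefore expected, an at least 2.5-fold lower number from compound 3 to compound 4 (0.39 log units; beyond the scatter). Compound 4 is estimated at 4000 nM, with a range of 1000 nM to 15000 nM.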

Compound 4, inhibition constant: 3870 nM
Compound 4: the middle estimate sits 1.0-fold (0.01 log units) above what was measured; the range from low to high includes it.
By their numbers in this assay, from the lowest: compound 2; then compound 1; then compound 4. At a limit, above all of these: compound 3.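

In this assay, 4-chlorophenyl in place of 2-chlorophenyl on a double-bonded nitrogen gives an at least 2.5-fold lower number from compound 3 to compound 4 (0.41 log units; beyond the scatter), so this exchange turns a result without a number into a measurable one. The result for compound 3 is a limit, so this step has no exact size: the limit of > 10000 nM in this assay, at which 1 of the 4 values shown sits. With 4-chlorophenyl held at that position, chloro in place of methyl on an aromatic carbon gives a 2.1-fold higher number from compound 1 to compound 4 (0.33 log units; beyond the scatter), a modest step.

Going by these compounds, whether a methoxy group or an amine on that phenyl ring would keep binding remains open.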